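The source may hold more compounds than are shown below. What is called first, only, known or untested is meant among the compounds shown, and "the series" means these compounds.

Measured compounds in an assay for inhibition of Indoleamine 2,3-dioxygenase 1 (Homo sapiens), with stated times of 10 min and 60 min; on this read-out lower numbers stand for stronger inhibition and higher numbers for weaker inhibition:
- compound 3 `FC(F)(F)c1cc(NC[C@@H]2CCCCN2)c2cn[nH]c2c1` gives 18700 nM
- compound 1 `Oc1ccc(CNc2cc(C(F)(F)F)cc3[nH]ncc23)cc1` gives 36700 nM
- compound 2 `OC1CCCC(Nc2cccc(CNc3cc(C(F)(F)F)cc4[nH]ncc34)c2)C1` gives > 100000 nM, which is a limit of the assay and not a number

Compound 3 stands at the lower of the two numbers, with compound 1 as its nearest neighbour: the step of a 2.0-fold lower number from compound 1 to compound 3 (0.29 log units; within the scatter) lies within the scatter. Compound 2 contributes only the limit (the limit of > 100000 nM in this assay, at which 1 of the 3 values shown sits).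

Compound 4 `FC(F)(F)c1cc(NCc2cccc(Br)c2)c2cn[nH]c2c1` differs from compound 3 by 3-bromophenyl in place of piperidin-2-yl on a saturated chain carbon bound to a nitrogen on an aromatic ring. Among the measured compounds shown here, the one measured step that bears on this place is a 2.0-fold lower number from compound 1 to compound 3 (0.29 log units; within the scatter), where an aromatic six-membered ring was exchanged for piperidin-2-yl without a change beyond the scatter. Compound 4 restores an aromatic six-membered ring of carbon only at that same position, so the step in this assay is expected to be small, running back toward the number of compound 1 rather than away from it. Compound 4 is therefore estimated at 30000 nM, between 10000 nM and 90000 nM, which means an expected step of a 1.6-fold higher number from compound 3 to compound 4 (0.21 log units; within the scatter).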

Compound 4, half-maximal inhibitory concentration: > 100000 nM
Compound 4: no number, only a limit; the forecaster's own chance of this, stated with the estimate: 10%; middle value at least 3.3-fold (0.52 log units) away from the limit.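

In this assay, this position proves sensitive to what replaces piperidin-2-yl: the earlier exchange stayed small, with a 2.0-fold lower number from compound 1 to compound 3 (0.29 log units; within the scatter), but the new change gives an at least 5.3-fold higher number from compound 3 to compound 4 (0.72 log units; beyond the scatter). An aromatic six-membered ring of carbon only does not by itself return the number to that of the hydroxylated aromatic analogue, since 3-bromophenyl in place of 4-hydroxyphenyl gives an at least 2.7-fold higher number from compound 1 to compound 4 (0.43 log units; beyond the scatter). Compound 4 gives a limit of the assay and not a number: the limit of > 100000 nM in this assay, at which 2 of the 4 values shown sit.

The step from compound 2 to compound 4 cannot be read, as both values are limits. The compounds shown leave open whether the loss follows the bromo group or its place on the ring, a question that an unsubstituted phenyl or a 3-hydroxyphenyl group would bear on.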